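The source may hold more compounds than are shown below. What is called first, only, known or untested is meant among the compounds shown, and "the series" means these compounds.

In a functional assay on UACC-903 cells (Homo sapiens) for antiproliferative activity, read by MTT assay, with a stated time of 48 h (a higher number here means a weaker inhibitor, a lower number a stronger inhibitor), compound 1 `CC(=O)Oc1ccccc1C(=O)NCC[Se]C#N` gives 4000 nM, the higher of the two actual numbers recorded. Compound 2 `CC(=O)Oc1ccccc1C(=O)[Se]CC[Se]C(=O)c1ccccc1OC(C)=O` gives 3600 nM, which lies within the scatter of that value, so the two cannot be ranked. Compound 3 `C[Se]CC(NC(=O)c1ccccc1OC(C)=O)C(=O)O` reaches only a limit of the assay, > 50000 nM. This is the case of the limit of > 50000 nM in this assay, at which 1 of the 3 values shown sits. Compound 4 `CC(=O)Oc1ccccc1C(=O)NCCSC#N` has not yet been measured. It differs from compound 1 by a group of 3 heavy atoms (1 carbon, 1 nitrogen, 1 sulfur; no ring) in place of a group of 3 heavy atoms (1 carbon, 1 nitrogen, 1 selenium; no ring), on a saturated chain carbon, two bonds along the chain from an amide-type nitrogen. For the measured compounds named here, no measured pair isolates such a swap, so no step size can be read from the data. For compound 4 a modest weakening is expected, with a 2.0-fold higher number from compound 1 to compound 4 (0.30 log units; within the scatter) near the edge of the scatter, giving an estimated 8000 nM with a likely range from 2500 nM to 30000 nM.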

Compound 4, half-maximal inhibitory concentration: > 50000 nM
Compound 4 gave a limit, no number; the forecaster's own chance of this, stated with the estimate: 15%; middle value at least 6.2-fold (0.79 log units) away from the limit.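

In this assay, exchanging selenium for sulfur in the group at this place, with the rest of compound 1 unchanged, gives an at least 12-fold higher number from compound 1 to compound 4 (1.09 log units; beyond the scatter). For the compounds shown here, this single-atom swap therefore separates a measurable antiproliferative effect from none that can be put as a number, which the earlier compounds could not show. The value of compound 4 is a limit, so the step has a known minimum but no known full size: the limit of > 50000 nM in this assay, at which 2 of the 4 values shown sit.

As far as these compounds go, whether an amine, a carboxylic acid or a longer chain at this place would keep the activity of compound 1 remains open.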